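This account rests on a few compounds, and the source may have more. Where it says the series, first, only, none or still open, it means among the compounds named here.

In a physicochemical assay for lipophilicity, read by HPLC, using the shake flask method (on this read-out lower numbers stand for lower lipophilicity and higher numbers for higher lipophilicity), compound 1 (`CCCCCN(Cc1ccc(Cl)nc1)/C(C)=N/C#N`) gives 2.37 while compound 2 (`C/C(=N\C#N)N(Cc1ccccc1)Cc1ccc(Cl)nc1`) gives 2.11 and compound 3 (`CCCCC/C(=N\C#N)N(C)Cc1ccc(Cl)nc1`) gives 2.3 on the same scale. All three sit within the scatter of one another, so compound 3 cannot be told apart from either of the others. Compound 4 (`CC(C)/C(=N\C#N)N(C)Cc1ccc(Cl)nc1`) departs from compound 3 in one place. The change is isopropyl in place of pentyl on a carbon with a double bond to nitrogen and amounts to isopropyl in place of pentyl on a carbon with a double bond to nitrogen.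

Within the data shown here, the only measured step is a number 0.26 log units lower from compound 1 to compound 2 (within the scatter) and it offers little guidance here. It concerns phenyl in place of butyl on a saturated chain carbon bound to an amine nitrogen, which is a different swap at a different place. The new change takes carbon away and brings in no hydrogen-bond donors or acceptors. From compound 3 at 2.3 a lower number is therefore expected in this assay with a step beyond the scatter. The estimated step is a number 0.90 log units lower from compound 3 to compound 4 (beyond the scatter) on this scale. For compound 4 the expected value is 1.4 with an estimated range from 1 to 1.8 on the same scale.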

Compound 4, partition coefficient: 1.39
Beside the measured number, compound 4's estimate is 0.01 log units above it; measured number inside the range.
By their numbers in this assay, from the lowest: compound 4; then compounds 2, 3 and 1 (each within the scatter of the next).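

In this assay, placing isopropyl where pentyl stood on a carbon with a double bond to nitrogen gives a number 0.91 log units lower from compound 3 to compound 4 (beyond the scatter). Among these compounds, this shows that the read-out can respond clearly to a change at this position, whereas the one earlier step, at a different place, stayed within the scatter. Neither pentyl nor isopropyl has a ring, a charge, or any hydrogen-bond donors or acceptors, and no measurement in hand explains the size of this step.

This single pair cannot separate the shorter carbon count of isopropyl from its branching, and an unbranched propyl chain at the same place would help to distinguish them. Going by these compounds, how a cyclopropyl ring, a methoxymethyl group or an amine would read at this position also remains open.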